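The source may report more compounds than this note shows. Statements on the series, on what has been measured and on what is new or still open speak of the compounds shown alone.

Measured in a functional assay on GC3/C1 cells (Homo sapiens) for cytotoxicity, read by MTT assay, with a stated time of 6 days; a lower number here means a stronger inhibitor, a higher number a weaker inhibitor:
- compound 1 `COc1ccc(NC(=O)SC[C@H](NC(C)=O)C(=O)O)cc1`: > 200000 nM, a limit of the assay
- compound 2 `CC(=O)N[C@@H](CSC(=O)Nc1ccccc1)C(=O)O`: 178000 nM
- compound 3 `CSc1ccccc1NC(=O)SC[C@H](NC(C)=O)C(=O)O`: > 200000 nM, a limit of the assay

Only compound 2 carries an actual number in this assay. From the compounds shown here alone, the other two compounds rest on (the limit of > 200000 nM in this assay, at which 2 of the 3 values shown sit), so the position of compound 2 relative to them remains open.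

Compound 4 `CC(=O)N[C@@H](CSC(=O)Nc1ccc(Cl)cc1)C(=O)O` has not yet been measured. It differs from compound 2 by a single change on the aromatic ring: chloro in place of hydrogen on an aromatic carbon. In words, this is chloro in place of hydrogen on an aromatic carbon, para to a large group.

Within the data shown here, two measured steps bear on this change, since both also exchange a hydrogen and a group on an aromatic carbon. One is an at least 1.1-fold lower number from compound 1 to compound 2 (0.05 log units; that floor lies within the scatter), with hydrogen in place of methoxy. The other is an at least 1.1-fold higher number from compound 2 to compound 3 (0.05 log units; that floor lies within the scatter), with methylsulfanyl in place of hydrogen. Both are only floors, and neither involves chloro, so they give no firm direction. The expectation is therefore for no step beyond the scatter, and a reading at the limit of the assay would not be a surprise.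

The estimated step is a 1.5-fold lower number from compound 2 to compound 4 (0.17 log units; within the scatter). For compound 4 the expected value is 120000 nM, with an estimated range from 50000 nM to 200000 nM.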

Compound 4, half-maximal inhibitory concentration: 8130 nM
Estimate against measurement, compound 4: 15-fold (1.17 log units) above; measured number outside the range, below it.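

In this assay, chloro on an aromatic carbon, para to a large group, gives a 22-fold lower number from compound 2 to compound 4 (1.34 log units; beyond the scatter). Among these compounds, this is the first step that clearly lies beyond the scatter, so a single group at this place can move the number strongly, which the floors seen with methoxy and methylsulfanyl could not show. Chloro in place of methoxy gives an at least 24-fold lower number from compound 1 to compound 4 (1.39 log units; beyond the scatter), and this step is only a floor, since compound 1 stands at a limit of the assay rather than at a number: the limit of > 200000 nM in this assay, at which 2 of the 4 values shown sit.

The compounds shown leave open whether this drop belongs to chloro in particular or would also appear with fluoro, bromo or trifluoromethyl at the same place, and whether chloro elsewhere on the ring would have the same effect. They also leave open how the rest of the shared core contributes, for instance whether a methyl ester in place of the carboxylic acid would keep the number seen for compound 4 in this assay.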